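The source may report more compounds than this note shows. Statements on the series, on what has been measured and on what is new or still open speak of the compounds shown alone.

Working notes on the series. In a functional assay on cells (T-cell, Homo sapiens) for inhibition (a lower number here means a stronger inhibitor, a higher number a weaker inhibitor), compound 1 `CC(C)Oc1nc(N)nc2ncc(-c3ccc(F)c(F)c3)nc12` gives 10000 nM, compound 2 `COc1ccc(-c2cnc3nc(N)nc(NC(C)C)c3n2)cc1OC` gives 600 nM, and compound 3 `COc1ccc(-c2cnc3nc(N)nc(N4CCN(c5cc(Cl)cc(Cl)c5)CC4)c3n2)cc1OC` gives 3400 nM. Compound 3 holds the second highest of the three numbers: compound 1 is nearest, with a higher number beyond the scatter, and compound 2 is furthest, with a lower number beyond the scatter. Compound 4 `COc1ccc(-c2cnc3nc(N)nc(N4CCN(C(=O)Nc5ccc(C)cc5)CC4)c3n2)cc1OC` follows from compound 3 by one change, ((4-methylphenyl)carbamoyl in place of 3,5-dichlorophenyl on an amine nitrogen in a ring). Within the data shown here, no measured pair in this set shows a change of this kind, so the size of the step rests on expectation alone. Expected is a modest lowering of the number in this assay, a 1.4-fold lower number from compound 3 to compound 4 (0.13 log units; within the scatter), with wide room either way. For compound 4 the estimate in this assay is 2500 nM, ranging from 600 nM to 10000 nM.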

Compound 4, half-maximal inhibitory concentration: 0.8 nM
For compound 4 the middle estimate is 3100-fold (3.49 log units) above the measured one, outside the stated range (below it).
By their numbers in this assay, from the lowest: compound 4; then compound 2; then compound 3; then compound 1.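

Replacing 3,5-dichlorophenyl with (4-methylphenyl)carbamoyl on the amine nitrogen in the ring gives in this assay a 4300-fold lower number from compound 3 to compound 4 (3.63 log units; beyond the scatter), so the group at this position can move the read-out very strongly. Both groups hold a six-membered aromatic ring of carbon only, so that ring alone does not set the number; the entering group adds a carbonyl and the amide hydrogen. Nothing at hand explains the size of this step.

The compounds shown leave open whether the carbonyl with its amide hydrogen or the 4-methyl carries the gain. Phenylcarbamoyl and benzoyl on the same nitrogen would separate these parts.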